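The source may report more compounds than this note shows. Statements on the series, on what has been measured and on what is new or still open speak of the compounds shown alone.

Measured in an assay on isolated protein for inhibition of Nitric oxide synthase, inducible (Homo sapiens), with a stated time of 30 min, tested at 1 mM; a lower number here means less inhibition, a higher number more inhibition at the concentration tested (going by the name of the read-out):

Compound 1, `Nc1cc(Cl)c(Cl)cc1C1=NN(C(=O)C2CC2)CC1`, gives 15.5%.
Compound 2, `Nc1cc(Cl)c(Cl)cc1C1=NN(C(=O)c2ccccc2)CC1`, gives 36.1%.
Compound 3, `COc1cc(N)c(C2=NN(C(=O)C3CC3)CC2)cc1OC`, gives 25.2%.

Compounds 1 and 2 share one core and differ only in phenyl in place of cyclopropyl on a carbonyl carbon. That change produced a number 20.6 percentage points higher from compound 1 to compound 2 (beyond the scatter). Compound 3 rests on another core; the difference between the two cores is not broken down here. Compound 4, `COc1cc(N)c(C2=NN(C(=O)c3ccccc3)CC2)cc1OC`, is not yet measured and carries the same change on the core of compound 3, namely (phenyl in place of cyclopropyl on a carbonyl carbon); the place is described in the same words both times, so it is the same change. Going by the values given here, only one earlier example of this change is available, so the expectation rests on that single step. Compound 4 is expected to show a number 19.8 percentage points higher from compound 3 to compound 4 (beyond the scatter) in this assay, because a number 20.6 percentage points higher from compound 1 to compound 2 (beyond the scatter) points that way. The estimate for compound 4 is therefore 45%, with a likely range from 30% to 60%.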

Compound 4, a percentage reported as inhibition, at one concentration (the size of the read-out at that concentration, not a potency): 28.9%
Compound 4: the middle estimate sits 16.1 percentage points above what was measured; the measured number lies below the stated range.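

Swapping cyclopropyl for phenyl on the carbonyl carbon gave a number 3.7 percentage points higher from compound 3 to compound 4 (within the scatter) in this assay, so on this core the effect of the change cannot be told apart from the usual scatter. The change therefore did not carry over at the same size from one core to the other: the same change on two cores in this assay, a number 20.6 percentage points higher (beyond the scatter) from compound 1 to compound 2 and a number 3.7 percentage points higher (within the scatter) from compound 3 to compound 4, 16.9 percentage points apart, beyond the scatter of two such steps

The size of this step thus depends on the core in these two pairs, but two pairs cannot show which difference between the cores is responsible, and these read-outs at one concentration say nothing about potency. As far as these compounds go, whether a longer chain or an amine on the carbonyl carbon would follow either step remains open. So does the size of the cyclopropyl-to-phenyl step on any third core.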